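The source may report more compounds than this note shows. Statements on the series, on what has been measured and on what is new or still open speak of the compounds shown alone.

Compound 3 `CC1=CC[C@H](C(C)(C)NC(=S)N/N=C(\C)c2ccccc2)CC1` stands apart from the other two measured compounds in a functional assay on NCI-H460 cells (Homo sapiens) for inhibition, read by sulforhodamine B assay, with a stated time of 48 h; on this read-out higher numbers stand for weaker inhibition of growth and lower numbers for stronger inhibition of growth. In this assay compound 3 gives > 100000 nM, which is a limit of the assay and not a number. Compound 1 `CC1=CC[C@H](C(C)(C)NC(=S)N/N=C/c2ccccc2)CC1` in this assay gives 13000 nM. Compound 2 `COc1ccc(/C=N/NC(=S)NC(C)(C)[C@H]2CC=C(C)CC2)cc1` in this assay gives 22500 nM. Among the compounds with values here, the only measured single-point step is a 1.7-fold higher number from compound 1 to compound 2 (0.24 log units; within the scatter). Compound 1 and compound 3 differ in more than one place, so their two values are simply set side by side, one a number and one a limit.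

The step followed here leads to compound 4 `CC1=CC[C@H](C(C)(C)NC(=S)N/N=C(\C)c2ccc([N+](=O)[O-])cc2)CC1`, which differs from compound 3 by nitro in place of hydrogen on an aromatic carbon. Within the data shown here, no measured step places a nitro group on this ring; the nearest guide is a 1.7-fold higher number from compound 1 to compound 2 (0.24 log units; within the scatter), a substitution on the same ring that stayed within the scatter. Compound 3 also sits at the limit of > 100000 nM in this assay, at which 1 of the 3 values shown sits, so a worsening could not even be read off. The expected step is therefore a number no higher from compound 3 to compound 4 (the limit leaves the size open), none beyond the scatter. Compound 4 is estimated at 100000 nM, with a range from 30000 nM to 300000 nM, and a limit rather than a number is the likelier outcome.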

Compound 4, concentration for 50% growth inhibition: 50800 nM
Beside the measured number, compound 4's estimate is 2.0-fold (0.29 log units) above it; the range from low to high includes it.
By their numbers in this assay, from the lowest: compounds 1 and 2 (each within the scatter of the next); then compound 4. At a limit, above all of these: compound 3.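

In this assay, within the data shown here, the change at this place gives an at least 1.9-fold lower number from compound 3 to compound 4 (0.29 log units; that floor lies within the scatter) and so supplies the first reading that starts from compound 3. It shows that nitro, on the aromatic carbon para to a large group, goes with a measured number where the hydrogen of compound 3 gave none, although the printed floor of the step does not by itself establish a gain beyond the usual variation between repeats. The only earlier step on an aromatic ring, a 1.7-fold higher number from compound 1 to compound 2 (0.24 log units; within the scatter), put methoxy in place of hydrogen and gave no such reading, while compound 3 gives > 100000 nM as a limit of the assay and not a number, so the full size of the new step stays unknown: the limit of > 100000 nM in this assay, at which 1 of the 4 values shown sits.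

The compounds shown leave open whether the number of compound 4 belongs to nitro in particular or whether an amine, a carboxylic acid or a chlorine atom at the same place on compound 3 would also give a number. They also leave open what nitro does on compound 1, where the starting point is a number and a step could be read in full.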